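Dimethylamino to diethylamino on the amide-bound chain carbon

The source may hold more compounds than are shown below. What is called first, only, known or untested is meant among the compounds shown, and "the series" means these compounds.

Measured so far in an ADME assay on 184B5 cells (Homo sapiens) for cytotoxicity, read by sulforhodamine B assay, with a stated time of 48 h; on this read-out lower numbers stand for stronger inhibition of growth and higher numbers for weaker inhibition of growth:
compound 1 `O=C1C(=O)N(CN(c2ccccc2)c2ccccc2)c2ccccc21`: 33700 nM
compound 2 `Cc1ccc2nc(/N=C3\C(=O)N(CN(C)C)c4cccc(Br)c43)sc2c1`: 74800 nM
compound 3 `CN(C)CN1C(=O)C(=O)c2c(Br)cccc21`: 77900 nM

Compound 3 gives the highest number of the three in this assay. Compound 2 lies within the scatter of compound 3, so the two cannot be separated on this read-out. Compound 1 gives a lower number than compound 3, and that gap lies beyond the scatter, so compound 1 inhibits growth more strongly than compound 3 in this assay. Among the compounds with values here, none of the three measured pairs differs in a single place, so no step between measured compounds is available to calibrate a change.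

Compound 4 `CCN(CC)CN1C(=O)C(=O)c2c(Br)cccc21` is the next member. Relative to compound 3 the change is diethylamino in place of dimethylamino on a saturated chain carbon bound to an amide-type nitrogen in a ring. Within the data shown here, no measured pair in this set shows the effect of such a change, so the step has to be set without a precedent. The step from compound 3 to compound 4 in this assay is expected to remain within the scatter, with no clear direction. The expected step is a 1.1-fold lower number from compound 3 to compound 4 (0.05 log units; within the scatter). Compound 4 is estimated at 70000 nM, with a range from 30000 nM to 160000 nM.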

Compound 4, concentration for 50% growth inhibition: 172000 nM
The estimate for compound 4 lay 2.5-fold (0.39 log units) below the measured number, and the stated range ends below it.
By their numbers in this assay, from the lowest: compound 1; then compounds 2 and 3 (each within the scatter of the next); then compound 4.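

In this assay the saturated chain carbon bound to an amide-type nitrogen in a ring now has its first calibrated change: diethylamino in place of dimethylamino gives a 2.2-fold higher number from compound 3 to compound 4 (0.34 log units; beyond the scatter), a modest step beyond the scatter towards weaker inhibition of growth. This place on the series therefore responds to a change in the groups on the amine nitrogen, at least for this one pair on the bromo-bearing core of compound 3. No measurement at hand accounts for the step.

On these data alone, whether the upward move continues with a longer chain such as dipropylamino, or with a ring amine such as piperidine or morpholine, stays open. As far as these compounds go, whether diethylamino has the same effect on the core of compound 2 also stays open.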